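Nitro in place of methylsulfonyl on shortened hydroxamate chain

A few compounds are considered here, and "the series" means these few. Any claim that something is new, unique, unknown or untested is made for them only; others in the source may bear on it.

Measured so far:
compound 1 `CS(=O)(=O)c1ccc2nc(NC(=O)CCCCCCC(=O)NO)sc2c1` — 15.4 ug/mL
compound 2 `CS(=O)(=O)c1ccc2nc(NC(=O)CCCCC(=O)NO)sc2c1` — > 30 ug/mL

In a functional assay on MCF7 cells (Homo sapiens) for cytotoxicity (a lower number here means a stronger inhibitor, a higher number a weaker inhibitor), compound 1 gives 15.4 ug/mL. Compound 2 gives only a limit in this assay, > 30 ug/mL, which is the limit of > 30 ug/mL in this assay, at which 1 of the 2 values shown sits. Within the data shown here, the one measured step is an at least 1.9-fold higher number from compound 1 to compound 2 (0.28 log units; that floor lies within the scatter), a change on the chain.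

Compound 3 `O=C(CCCCC(=O)Nc1nc2ccc([N+](=O)[O-])cc2s1)NO` differs from compound 2 by nitro in place of methylsulfonyl on an aromatic carbon. Among the measured compounds shown here, no measured step touches this aromatic substituent, so nothing here indicates a direction for this assay; no step beyond the scatter is assumed. Compound 3 is expected near 30 ug/mL (range 12 ug/mL to 75 ug/mL), a step of a number no higher from compound 2 to compound 3 (the limit leaves the size open), with a fair chance that only a limit is reported again.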

Compound 3, half-maximal inhibitory concentration: > 30 ug/mL
Compound 3 gave a limit, no number; the forecaster's own chance of this, stated with the estimate: 60%; the middle value lies on the limit itself.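

Compound 2 and compound 3 both give only a limit in this assay, so no step can be read between them: the limit of > 30 ug/mL in this assay, at which 2 of the 3 values shown sit.

Going by these compounds, whether nitro in place of methylsulfonyl shifts the number in this assay at all remains open.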